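Taking One Fluoro Away from Compound 3

A few compounds are considered here, and "the series" means these few. Any claim that something is new, unique, unknown or untested is made for them only; others in the source may bear on it.

- compound 1 `Cc1cc(NC(=O)Nc2ccccc2N)c2ccccc2n1` gives 51800 nM
- compound 2 `Cc1ccc(NC(=O)Nc2cc(C)nc3ccccc23)cc1` gives 1300 nM
- compound 3 `Cc1cc(NC(=O)Nc2ccc(F)c(F)c2)c2ccccc2n1` gives 500 nM

In a physicochemical assay for solubility, at pH 7.4 (a lower number here means a less soluble compound, a higher number a more soluble compound), compound 3 (500 nM) has the lowest number of the three, under compound 2 and far under compound 1. Compound 4 `Cc1cc(NC(=O)Nc2ccc(F)cc2)c2ccccc2n1` differs from compound 3 in one place (hydrogen in place of fluoro on an aromatic carbon), with hydrogen in place of fluoro on an aromatic carbon.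

Within the data shown here, only one measured step compares two compounds that differ in one place (a 40-fold lower number from compound 1 to compound 2 (1.60 log units; beyond the scatter)). It is large, but it swaps a different group, so it is weak guidance here. Among the measured compounds shown here, no measured step shows the loss of a fluoro alone. Compound 2 (1300 nM) also carries a single group on that aromatic ring, which suggests a modest rise rather than a large one. A small step towards a higher number is therefore expected (a 1.8-fold higher number from compound 3 to compound 4 (0.26 log units; within the scatter)), possibly no larger than the scatter. For compound 4 the estimated value is 900 nM (expected range 350 nM to 2300 nM).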

Compound 4, solubility: 3700 nM
Compound 4: the middle estimate sits 4.1-fold (0.61 log units) below what was measured, outside the stated range (above it).
By their numbers in this assay, from the lowest: compound 3; then compound 2; then compound 4; then compound 1.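

In this assay the loss of one fluoro alone, from the aromatic carbon ortho to a fluoro group and meta to a large group, gives a 7.4-fold higher number from compound 3 to compound 4 (0.87 log units; beyond the scatter) and so shows that this single place on the ring can move the number beyond the scatter. The ring of compound 4 can also be read against other groups: a 2.8-fold higher number from compound 2 to compound 4 (0.45 log units; beyond the scatter) goes with fluoro in place of methyl, and a 14-fold lower number from compound 1 to compound 4 (1.15 log units; beyond the scatter) goes with 4-fluorophenyl in place of 2-aminophenyl, which places compound 4 between compound 2 and compound 1. No supporting measurement bears on these steps, so they stand as observations only.

The compounds shown leave open whether taking away the other fluoro alone would give a step of similar size. They also leave open what a chloro, a methoxy or a nitrile would give at this place on the ring.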